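Methoxy in Place of Iodo on a Shared Core

A few compounds are considered here, and "the series" means these few. Any claim that something is new, unique, unknown or untested is made for them only; others in the source may bear on it.

Compound 1, `CCCNC/C=C(/c1ccc(Br)cc1)c1cccnc1`: in a functional assay on brain for inhibition of Norepinephrine transporter (Rattus norvegicus) (on this read-out lower numbers stand for stronger inhibition and higher numbers for weaker inhibition), compound 1 gives > 24000 nM, which is a limit of the assay.
Compound 2, `CN(C)C/C=C(/c1ccc(I)cc1)c1cccnc1`: in this assay compound 2 gives > 22000 nM, likewise a limit.

Compound 2 thus sits at the limit of > 22000 nM in this assay, at which 1 of the 2 values shown sits, and compound 1 sits at the limit of > 24000 nM in this assay, at which 1 of the 2 values shown sits, so no number is known for either. Compound 3, `COc1ccc(/C(=C/CN(C)C)c2cccnc2)cc1`, differs from compound 2 by methoxy in place of iodo on an aromatic carbon. For the measured compounds named here, no step between measured compounds is available, and in this assay no change beyond the scatter is expected. Compound 3 is estimated at 25000 nM, between 5000 nM and 100000 nM. The expected step is a step that the limit leaves unreadable from compound 2 to compound 3, most likely again reported only as a limit.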

Compound 3, half-maximal inhibitory concentration: > 28000 nM
Compound 3 was reported as a limit; the forecaster's own chance of this, stated with the estimate: 75%; middle value at least 1.1-fold (0.04 log units) from the limit.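

For the compounds shown here, compound 2 and compound 3 are both reported only as limits, so no step between them can be read. The compounds shown leave open what actual value any of them would give in this assay.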